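Aryl swap on the pyridazinone of a quinoline ether series

The source may hold more compounds than are shown below. What is called first, only, known or untested is meant among the compounds shown, and "the series" means these compounds.

Measured compounds:
compound 1 `COc1cc2c(Oc3ccc(NC(=O)c4nn(-c5ccccc5C)c(=O)cc4C)cc3F)ccnc2cc1OCCCN1CCCC1` 1400 nM
compound 2 `COc1cc2c(Oc3ccc(NC(=O)c4nn(-c5ccccc5C)c(=O)cc4C)cc3F)ccnc2cc1OCCCN1CCC(C)CC1` 2810 nM
compound 3 `COc1cc2c(Oc3ccc(NC(=O)c4nn(-c5ccccc5C)c(=O)cc4C)cc3F)ccnc2cc1OCCCN1CCN(C)CC1` 3790 nM

In a functional assay on HT-29 cells (Homo sapiens) for inhibition, read by MTT assay, with a stated time of 72 h (a higher number here means a weaker inhibitor, a lower number a stronger inhibitor), compound 3 gives the highest number of the three; the step of a 1.3-fold higher number from compound 2 to compound 3 (0.13 log units; within the scatter) is within the scatter, whereas a 2.7-fold higher number from compound 1 to compound 3 (0.43 log units; beyond the scatter) lies beyond it. Compound 4 `COc1cc2c(Oc3ccc(NC(=O)c4nn(-c5cccc(F)c5)c(=O)cc4C)cc3F)ccnc2cc1OCCCN1CCN(C)CC1` differs from compound 3 at another place: 3-fluorophenyl in place of 2-methylphenyl on an aromatic nitrogen. Among the compounds with values here, none of the measured steps touches this aryl group; all three alter the amine at the end of the chain, as in a 2.0-fold higher number from compound 1 to compound 2 (0.30 log units; within the scatter). With nothing measured on this change, no step beyond the scatter is expected in this assay, in either direction, and the uncertainty is wide. Compound 4 is therefore estimated at 3800 nM, within 1300 nM to 11000 nM, corresponding to an expected step of a 1.0-fold higher number from compound 3 to compound 4 (0.00 log units; within the scatter).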

Compound 4, half-maximal inhibitory concentration: 250 nM
Compound 4: the middle estimate sits 15-fold (1.18 log units) above what was measured, outside the stated range (below it).
By their numbers in this assay, from the lowest: compound 4; then compounds 1, 2 and 3 (each within the scatter of the next, the first and the last beyond it).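

The aryl group on the aromatic nitrogen proves a far stronger lever than the amine at the chain end: in this assay, 3-fluorophenyl in place of 2-methylphenyl gives a 15-fold lower number from compound 3 to compound 4 (1.18 log units; beyond the scatter) and so exceeds the largest amine step, a 2.7-fold higher number from compound 1 to compound 3 (0.43 log units; beyond the scatter) in the same assay. Both groups count the same heavy atoms and no hydrogen-bond donors or acceptors, so these counts do not separate them. No measurement at hand accounts for the gain.

The compounds shown leave open whether losing the methyl or gaining the fluorine matters, which plain phenyl or 2-fluorophenyl could settle. They also leave open whether the gain carries over to the pyrrolidin-1-yl and 4-methylpiperidin-1-yl chain ends.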